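From phenyl to 2-(dimethylamino)ethyl on compound 3

This account rests on a few compounds, and the source may have more. Where it says the series, first, only, none or still open, it means among the compounds named here.

In a functional assay on the whole organism for antagonist activity, with Mus musculus as the target (on this read-out lower numbers stand for an effect already at smaller amounts and higher numbers for an effect only at larger amounts of compound), compound 1 `CCNC1CCCC1N(C(=O)CC)c1ccc(Cl)c(Cl)c1` gives 2 mg/kg as its dose, and compound 2 `C=CCNC1CCCC1N(C(=O)CC)c1ccc(Cl)c(Cl)c1` gives 3 mg/kg as its dose. These two are separated only by a 1.5-fold higher number from compound 1 to compound 2 (0.18 log units; within the scatter) and count as no real difference. Compound 3 `CCC(=O)N(c1ccc(Cl)c(Cl)c1)C1CCCC1N(C)Cc1ccccc1` stands highest of the three at 40 mg/kg on this scale. It carries benzyl(methyl)amino on a saturated ring carbon where the other two carry ethylamino and allylamino. That exchange goes with a 20-fold higher number from compound 1 to compound 3 (1.30 log units; beyond the scatter) and with a 13-fold higher number from compound 2 to compound 3 (1.12 log units; beyond the scatter) in the data, and both steps are large.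

Compound 4 `CCC(=O)N(c1ccc(Cl)c(Cl)c1)C1CCCC1N(C)CCCN(C)C` is still unmeasured. In it, 2-(dimethylamino)ethyl takes the place of phenyl on a saturated chain carbon bound to an amine nitrogen (2-(dimethylamino)ethyl in place of phenyl on a saturated chain carbon bound to an amine nitrogen). Going by the values given here, no measured step replaces phenyl itself, so the evidence is indirect. The large steps exchanged the whole amino group, whereas compound 4 keeps the methyl on the amine nitrogen of compound 3 at 40 mg/kg and changes only the far part of the chain. The expected size is a 1.3-fold lower number from compound 3 to compound 4 (0.12 log units; within the scatter) and so no step beyond the scatter is expected in this assay here. For compound 4 the estimated dose is 30 mg/kg with an expected range from 8 mg/kg to 100 mg/kg on this read-out.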

Compound 4, dose for half-maximal effect: 10 mg/kg
Compound 4: the middle estimate sits 3.0-fold (0.48 log units) above what was measured; low and high end bracket the measured number.
By their numbers in this assay, from the lowest: compounds 1 and 2 (each within the scatter of the next); then compound 4; then compound 3.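

In this assay the far end of the group on the amine nitrogen turns out to matter on its own: with the methyl on that nitrogen kept, 2-(dimethylamino)ethyl in place of phenyl gives a 4.0-fold lower number from compound 3 to compound 4 (0.60 log units; beyond the scatter) and so moves the number beyond the scatter. Exchanging the whole amino group is also not always a large step, since (3-(dimethylamino)propyl)(methyl)amino gives only a 3.3-fold higher number from compound 2 to compound 4 (0.52 log units; beyond the scatter) in place of allylamino and a 5.0-fold higher number from compound 1 to compound 4 (0.70 log units; beyond the scatter) in place of ethylamino, both modest, whereas the same exchanges with benzyl(methyl)amino were large. Nothing measured here speaks to the reason for either shift.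

This single change removes an aromatic ring of carbon only and brings in a nitrogen at the same time, so the compounds shown cannot tell which of the two goes with the lower number. A butyl chain of carbon only or a cyclohexyl ring at this place would separate the two, and a shorter chain ending in dimethylamino would show whether the length of the chain also counts.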